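From Oxolane to Methylpyrrolidine on the Side Chain

This account rests on a few compounds, and the source may have more. Where it says the series, first, only, none or still open, it means among the compounds named here.

In a functional assay on RS4-11 cells (Homo sapiens) for inhibition, read by CCK-8 assay, with a stated time of 72 h (a lower number here means a stronger inhibitor, a higher number a weaker inhibitor), compound 1 (`CC1(C)CCC(CN2CCN(c3ccc(C(=O)NS(=O)(=O)c4ccc(OC5CCOCC5)c([N+](=O)[O-])c4)c(Oc4cnc5[nH]ccc5c4)c3)CC2)=C(c2ccc(C(F)(F)F)cc2)C1`) gives 375 nM, while compound 2 (`CC1(C)CCC(CN2CCN(c3ccc(C(=O)NS(=O)(=O)c4ccc(OCC5CCOC5)c([N+](=O)[O-])c4)c(Oc4cnc5[nH]ccc5c4)c3)CC2)=C(c2ccc(C(F)(F)F)cc2)C1`) gives 47 nM, the lower of the two numbers. Compound 3 (`CN1CCC(COc2ccc(S(=O)(=O)NC(=O)c3ccc(N4CCN(CC5=C(c6ccc(C(F)(F)F)cc6)CC(C)(C)CC5)CC4)cc3Oc3cnc4[nH]ccc4c3)cc2[N+](=O)[O-])C1`) carries 1-methylpyrrolidin-3-yl in place of oxolan-3-yl on a saturated chain carbon bound to an oxygen on an aromatic ring. For the measured compounds named here, the only measured step, an 8.0-fold lower number from compound 1 to compound 2 (0.90 log units; beyond the scatter), altered the same substituent, but no measured compound holds the entering group. A small rise in this assay is therefore expected, with an estimated step of a 2.1-fold higher number from compound 2 to compound 3 (0.33 log units; beyond the scatter). Compound 3 is estimated at 100 nM, within an expected range of 25 nM to 400 nM.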

Compound 3, half-maximal inhibitory concentration: 10 nM
Compound 3: middle estimate off by 10-fold (1.00 log units), on the high side; the measured number lies below the stated range.
By their numbers in this assay, from the lowest: compound 3; then compound 2; then compound 1.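

In this assay, replacing oxolan-3-yl with 1-methylpyrrolidin-3-yl gives a 4.7-fold lower number from compound 2 to compound 3 (0.67 log units; beyond the scatter) at this place, so the number falls further when the ring oxygen gives way to a methylated ring nitrogen. Measured against the oxan-4-yl group, the (1-methylpyrrolidin-3-yl)methyl group gives a 38-fold lower number from compound 1 to compound 3 (1.57 log units; beyond the scatter) and is the largest step seen on this side chain. Nothing available here accounts for this result.

As far as these compounds go, it remains open whether the ring nitrogen or its methyl group carries the change. The unsubstituted pyrrolidin-3-yl ring or an open-chain dimethylamine on the same chain would help separate the two.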